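The compounds below may be only part of what the source reports. "The series", "measured", "known", "first", "only" and "open" are said of these compounds alone.

Compound 1 `Fc1ccc(CSc2nc(-c3ccc(Br)cc3)cc(-c3ccc(Br)cc3)n2)cc1` and compound 2 `Clc1ccccc1CSc1nc(-c2ccc(Br)cc2)cc(-c2ccc(Br)cc2)n1` share one core and differ only in the group on the chain carbon bound to the sulfur. In an assay on isolated protein for inhibition of Alpha glucosidase (Homo sapiens), read by spectrophotometry, with stated times of 15 min and 30 min (on this read-out higher numbers stand for weaker inhibition and lower numbers for stronger inhibition), compound 1 gives 19000 nM, and compound 2 gives 19000 nM. The change 2-chlorophenyl in place of 4-fluorophenyl on a saturated chain carbon bound to a sulfur thus gave the step of no change at the digits printed from compound 1 to compound 2 (within the scatter). Compound 3 `Cc1ccc(-c2cc(-c3cccc(Br)c3)nc(SCc3ccc(F)cc3)n2)cc1` is built on a different core; how the two cores differ is not broken down here. In this assay compound 3 gives 19000 nM. Compound 4 `Cc1ccc(-c2cc(-c3cccc(Br)c3)nc(SCc3ccccc3Cl)n2)cc1` has not yet been measured. It arises from compound 3 by the same change, (2-chlorophenyl in place of 4-fluorophenyl on a saturated chain carbon bound to a sulfur), at the same place. Because the step of no change at the digits printed from compound 1 to compound 2 (within the scatter) stayed within the scatter, an equally flat step is expected here, no change at the digits printed from compound 3 to compound 4 (within the scatter). Compound 4 is therefore estimated at 19000 nM in this assay, with a likely range from 9000 nM to 40000 nM.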

Compound 4, half-maximal inhibitory concentration: 19000 nM
Compound 4: middle estimate and measured number agree at the digits printed; the range from low to high includes it.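

In this assay, putting 2-chlorophenyl in place of 4-fluorophenyl on the chain carbon bound to the sulfur gave no change at the digits printed from compound 3 to compound 4 (within the scatter). Set beside the earlier step, the same change reads alike on both cores: the same change on two cores in this assay, no change at the digits printed (within the scatter) from compound 1 to compound 2 and no change at the digits printed (within the scatter) from compound 3 to compound 4, 1.0-fold (0.00 log units) apart, within the scatter of two such steps. This shows that the change left the reading flat on these two cores, but all four compounds print the same value, so it does not show whether a change that really moved the number would carry over in the same way, or whether this one would stay flat on a further core.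

The compounds shown leave open what an amine, a carboxylic acid or a longer chain would do in place of the 2-chlorophenyl on that saturated chain carbon. Only these two aromatic groups appear at that place, so the series says nothing yet about which groups there could give a stronger or weaker reading.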